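This account rests on a few compounds, and the source may have more. Where it says the series, first, only, none or still open, it means among the compounds named here.

In an ADME assay on MDBK cells (Bos taurus) for cytotoxicity, read by MTT assay, with a stated time of 96 h (on this read-out higher numbers stand for lower toxicity in this test and lower numbers for higher toxicity in this test), compound 3 `Fc1ccc(NC(=S)Nc2cccc(C(F)(F)F)c2)cc1` gives 41000 nM, the highest of the two plain numbers in hand. Compound 2 `FC(F)(F)c1cccc(NC(=S)Nc2ccc(Cl)cc2)c1` gives 17000 nM, so there is a 2.4-fold higher number from compound 2 to compound 3 (0.38 log units; beyond the scatter). Compound 1 `Fc1ccccc1NC(=S)Nc1cccc(C(F)(F)F)c1` yields only a limit, > 100000 nM, as the limit of > 100000 nM in this assay, at which 1 of the 3 values shown sits, records. Compound 4 `CC(=O)NC(=S)Nc1cccc(C(F)(F)F)c1` is not yet measured; it differs from compound 3 by acetyl in place of 4-fluorophenyl on an amide-type nitrogen. The measured steps of an at least 2.4-fold lower number from compound 1 to compound 3 (0.38 log units; beyond the scatter) and a 2.4-fold higher number from compound 2 to compound 3 (0.38 log units; beyond the scatter) each swapped one substituted phenyl for another, whereas here the whole 4-fluorophenyl leaves and an acetyl takes its place, so those steps bear on it only loosely. A step of a 1.6-fold higher number from compound 3 to compound 4 (0.20 log units; within the scatter) is expected, in the direction of lower toxicity. Compound 4 is therefore estimated at 65000 nM, within a range from 20000 nM to 200000 nM.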

Compound 4, half-maximal cytotoxic concentration: > 100000 nM
Compound 4 was reported as a limit (the forecaster's own chance of this, stated with the estimate: 35%); middle value at least 1.5-fold (0.18 log units) from the limit.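

On this amide-type nitrogen, an acetyl can stand in place of a substituted phenyl ring, and in this assay this gives an at least 2.4-fold higher number from compound 3 to compound 4 (0.38 log units; beyond the scatter) and an at least 5.8-fold higher number from compound 2 to compound 4 (0.76 log units; beyond the scatter). For the compounds shown here, the earlier compounds only swapped one substituted phenyl for another, so this is the first look at a group with no ring here, yet compound 1 keeps its phenyl and still reaches the limit. Compound 4 gives a limit, not a number, and its step from compound 1 cannot be read: the limit of > 100000 nM in this assay, at which 2 of the 4 values shown sit.

Open, on these data alone, is how a longer acyl chain, a benzoyl or a simple amine would fare on this nitrogen. Also open, as far as these compounds go, is how far compound 1 and compound 4 lie past the limit.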